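This account rests on a few compounds, and the source may have more. Where it says the series, first, only, none or still open, it means among the compounds named here.

Measured in a functional assay on MDA-MB-231 cells (Homo sapiens) for antiproliferative activity, read by MTT assay, with a stated time of 72 h; a lower number here means a stronger inhibitor, a higher number a weaker inhibitor:
Compound 1 `O=C(CCc1cccc2c1B(O)OC2)NC1CCCCC1`: > 100000 nM, a limit
Compound 2 `O=C(CCc1cccc2c1B(O)OC2)Nc1nccs1`: > 100000 nM, a limit

Compound 2 therefore has no number of its own. It stands with compound 1 in the limit of > 100000 nM in this assay, at which 2 of the 2 values shown sit, so neither measured compound shows any activity that can be read as a value. Compound 3 `O=C(CCc1cccc2c1B(O)OC2)Nc1ccc(I)cc1` keeps the shared core and differs from compound 2 by 4-iodophenyl in place of 1,3-thiazol-2-yl on an amide-type nitrogen. Going by the values given here, the only measured step at this amide-type nitrogen is a step that the two limits leave unreadable from compound 1 to compound 2, and it supplies no size to carry over. Among the compounds with values here, nothing measured so far shows that changing this group moves this assay at all. The most likely outcome is thus that the new group leaves the result at the limit, or gives only a weak reading just inside it. Any readable value could lie only on the stronger side of the limit, so a modest gain is the one direction expected. For compound 3 the estimated value is 70000 nM, with an expected range from 15000 nM to 100000 nM. This estimate means an expected at least 1.4-fold lower number from compound 2 to compound 3 (0.15 log units; that floor lies within the scatter).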

Compound 3, half-maximal inhibitory concentration: 33000 nM
Estimate against measurement, compound 3: 2.1-fold (0.33 log units) above, and the stated range covers the measured number.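

In this assay, the amide-type nitrogen is now shown to be a place where a change can move the result, which the earlier pair could not show because its step could not be read. Putting 4-iodophenyl in place of 1,3-thiazol-2-yl gives an at least 3.0-fold lower number from compound 2 to compound 3 (0.48 log units; beyond the scatter), and putting it in place of cyclohexyl gives an at least 3.0-fold lower number from compound 1 to compound 3 (0.48 log units; beyond the scatter); both steps are beyond the scatter, but each is only a floor on the true size. Compound 3 is the only one of the three with a number of its own, while the other two remain at a limit: the limit of > 100000 nM in this assay, at which 2 of the 3 values shown sit.

The compounds shown leave open whether the gain belongs to the iodine or to the six-membered carbon ring, a question that a plain phenyl, a 4-chlorophenyl or a 4-methoxyphenyl group on this nitrogen would address. They also leave open how much further this position can carry the activity from compound 3, which gives 33000 nM, and whether any change to the propanamide chain or the shared core would add to it.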